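The compounds below may be only part of what the source reports. "The series", "measured", "known", "first", "only" and "open" are said of these compounds alone.

Measured so far:
- compound 1, `COc1ccc(N/C(CCNC2=CC(=O)c3ccccc3C2=O)=N\S(=O)(=O)c2ccc(C)cc2)cc1`: 25500 nM
- compound 2, `Cc1ccc(S(=O)(=O)/N=C(/CCNC2=CC(=O)c3ccccc3C2=O)Nc2ccc(Cl)cc2)cc1`: 29900 nM
- compound 3, `COc1ccc(N/C(CCNC2=CC(=O)c3ccccc3C2=O)=N\S(=O)(=O)c2ccc(C)cc2)cc1OC`: 20500 nM

All three were tested in a functional assay on A549 cells (Homo sapiens) for cytotoxicity, read by MTT assay, with a stated time of 48 h; a higher number here means a weaker inhibitor, a lower number a stronger inhibitor. Compound 3 has the lowest number of the three, yet its distance to the others is small: a 1.2-fold lower number from compound 1 to compound 3 (0.09 log units; within the scatter) and a 1.5-fold lower number from compound 2 to compound 3 (0.16 log units; within the scatter). Likewise a 1.2-fold higher number from compound 1 to compound 2 (0.07 log units; within the scatter). So far, changing the substituents on the aryl group attached to the amine nitrogen has produced nothing beyond the scatter.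

Compound 4, `COc1ccc(N/C(CCNC2=CC(=O)c3ccccc3C2=O)=N\S(=O)(=O)c2ccc(C)cc2)c(OC)c1`, has not yet been measured. It differs from compound 3 in one place: 2,4-dimethoxyphenyl in place of 3,4-dimethoxyphenyl on an amine nitrogen. The atoms are the same; only the arrangement of the two methoxy groups on that ring changes.

Among the compounds with values here, none of the measured steps moves a group from one ring position to another, so there is no direct precedent. The nearest guides are the steps into compound 3, which add a methoxy group or exchange the whole aryl group, and both stayed within the scatter. On that basis no step beyond the scatter is expected in this assay, in either direction: a 1.1-fold higher number from compound 3 to compound 4 (0.03 log units; within the scatter). For compound 4 the estimated value is 22000 nM, with a range from 10000 nM to 48000 nM.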

Compound 4, half-maximal inhibitory concentration: 126000 nM
For compound 4 the middle estimate is 5.7-fold (0.76 log units) below the measured one, and the stated range ends below it.
By their numbers in this assay, from the lowest: compounds 3, 1 and 2 (each within the scatter of the next); then compound 4.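

In this assay, the arrangement of the methoxy groups on this aryl group matters even though the atoms stay the same: 2,4-dimethoxyphenyl in place of 3,4-dimethoxyphenyl on the amine nitrogen gives a 6.1-fold higher number from compound 3 to compound 4 (0.79 log units; beyond the scatter), which is beyond the scatter, unlike every earlier step. The same kind of change, methoxy in place of hydrogen on an aromatic carbon, therefore has an outcome that depends on the carbon involved: it stays within the scatter at a 1.2-fold lower number from compound 1 to compound 3 (0.09 log units; within the scatter), yet gives a 4.9-fold higher number from compound 1 to compound 4 (0.69 log units; beyond the scatter), and compound 4 also separates from the chloro compound with a 4.2-fold higher number from compound 2 to compound 4 (0.62 log units; beyond the scatter), making it the weakest of the four. No measurement is available here that accounts for this shift.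

The compounds shown leave open whether the higher number belongs to methoxy itself or to any group placed in the same pattern, as ethoxy or hydroxyl groups in place of the two methoxy groups of the 2,4-dimethoxyphenyl could show. They also leave open whether the same shift would appear with a longer chain between the shared core and the amidine carbon.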